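Swapping the polyamine chain on compound 1

The compounds below may be only part of what the source reports. "The series", "measured", "known", "first", "only" and "open" are said of these compounds alone.

- compound 1 `COc1cc(C(=O)/C=C/c2ccc(OCCCC(=O)NCCCCN(CCCN)CCCCN)cc2)cc(OC)c1OC`: 87200 nM
- compound 2 `COc1ccc(/C=C/C(=O)c2cc(OC)c(OC)c(OC)c2)cc1OCCCC(=O)NCCCNCCCCNCCN`: > 100000 nM (a limit, not a number)
- compound 3 `COc1ccc(/C=C/C(=O)c2cc(OC)c(OC)c(OC)c2)cc1OCCCC(=O)NCCCCN(CCCN)CCCCNCCCN`: 89100 nM

In a functional assay on HT-29 cells (Homo sapiens) for antiproliferative activity, read by MTT assay, with a stated time of 48 h (on this read-out lower numbers stand for stronger inhibition and higher numbers for weaker inhibition), compound 1 gives 87200 nM and compound 3 gives 89100 nM, two values within the usual scatter of each other. Compound 1 therefore stands level with compound 3. Compound 2 can be placed only by its limit of > 100000 nM.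

The unmeasured compound 4 `COc1cc(C(=O)/C=C/c2ccc(OCCCC(=O)NCCCNCCCCNCCN)cc2)cc(OC)c1OC` keeps the core of compound 1 and changes the chain: (4-((2-aminoethyl)amino)butyl)amino in place of ((4-aminobutyl)(3-aminopropyl)amino)methyl on a saturated chain carbon, three bonds along the chain from an amide-type nitrogen. In words, (4-((2-aminoethyl)amino)butyl)amino stands in place of ((4-aminobutyl)(3-aminopropyl)amino)methyl on a saturated chain carbon, three bonds along the chain from an amide-type nitrogen.

Within the data shown here, no measured step shows what such a swap does in this assay, so the three results above are the only guide. A change no larger than the scatter is expected, with no firm direction: a 1.1-fold higher number from compound 1 to compound 4 (0.04 log units; within the scatter). The estimate for compound 4 is 95000 nM, with an expected range of 60000 nM to 140000 nM.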

Compound 4, half-maximal inhibitory concentration: 98000 nM
Beside the measured number, compound 4's estimate is 1.0-fold (0.01 log units) below it; the measured number falls inside the stated range.
By their numbers in this assay, from the lowest: compounds 1, 3 and 4 (each within the scatter of the next). At a limit, above all of these: compound 2.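

In this assay, among these compounds, this change gives the first measured step at this position: a 1.1-fold higher number from compound 1 to compound 4 (0.05 log units; within the scatter). Thus, on a saturated chain carbon, three bonds along the chain from an amide-type nitrogen, (4-((2-aminoethyl)amino)butyl)amino can stand in place of ((4-aminobutyl)(3-aminopropyl)amino)methyl without a readable change, even though the group goes from 11 heavy atoms to 9 and from 2 hydrogen-bond donors to 3. Compound 2 gives a limit rather than a number: the limit of > 100000 nM in this assay, at which 1 of the 4 values shown sits.

The compounds shown leave open whether a much shorter group at this place, such as a single primary amine, would give a clearly different number. They also leave open what a carboxylic acid at the end of the chain would do.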